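Position of the acid on the pendant phenyl ring

This account rests on a few compounds, and the source may have more. Where it says the series, first, only, none or still open, it means among the compounds named here.

Compound 1 `COC(=O)c1ccccc1-c1ccc(CSc2nc(C(C)C)nc3ccccc23)cc1`: in an assay on isolated protein for inhibition of phosphodiesterase 7 (Homo sapiens), read by scintillation proximity assay and cAMP accumulation, with a stated time of 1 h (on this read-out lower numbers stand for stronger inhibition and higher numbers for weaker inhibition), compound 1 gives > 100000 nM, which is a limit of the assay and not a number.
Compound 2 `COC(=O)c1ccc(-c2ccc(CSc3nc(C(C)C)nc4ccccc34)cc2)cc1`: compound 2 gives 33000 nM.
Compound 3 `CC(C)c1nc(SCc2ccc(-c3ccccc3C(=O)O)cc2)c2ccccc2n1`: compound 3 gives 44000 nM.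

Compound 3 holds the higher of the two numbers given, and its nearest neighbour is compound 2, with a 1.3-fold higher number from compound 2 to compound 3 (0.12 log units; within the scatter). For the measured compounds named here, the only other value, that of compound 1, is a limit.

Compound 4 `CC(C)c1nc(SCc2ccc(-c3cccc(C(=O)O)c3)cc2)c2ccccc2n1` differs from compound 3 by 3-carboxyphenyl in place of 2-carboxyphenyl on an aromatic carbon, the entering group sitting on an aromatic carbon of a six-membered aromatic ring of carbon only, para to a large group. The step that bears on this shift is the move of the ester group, an at least 3.0-fold lower number from compound 1 to compound 2 (0.48 log units; beyond the scatter), whose size is known only as a bound because of the limit of > 100000 nM in this assay, at which 1 of the 3 values shown sits. The ester-to-acid step an at least 2.2-fold lower number from compound 1 to compound 3 (0.35 log units; beyond the scatter) is also bounded for the same reason. Going by the values given here, no measured compound carries the 3-substituted ring, so the size of the shift is estimated rather than read off: a modest lowering, a 1.8-fold lower number from compound 3 to compound 4 (0.25 log units; within the scatter), is expected. Compound 4 is expected to give about 25000 nM, with a range from 8000 nM to 80000 nM.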

Compound 4, half-maximal inhibitory concentration: 850 nM
Compound 4: middle estimate off by 29-fold (1.47 log units), on the high side, and the stated range ends above it.
By their numbers in this assay, from the lowest: compound 4; then compounds 2 and 3 (each within the scatter of the next). At a limit, above all of these: compound 1.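

In this assay, for the compounds shown here, where the carboxyl group sits on the pendant ring proves decisive: with the same atoms joined differently, 3-carboxyphenyl in place of 2-carboxyphenyl gives a 52-fold lower number from compound 3 to compound 4 (1.71 log units; beyond the scatter), a change that the earlier compounds did not reveal. The 3-carboxyphenyl ring also separates clearly from the 4-(methoxycarbonyl)phenyl ring, with a 39-fold lower number from compound 2 to compound 4 (1.59 log units; beyond the scatter), whereas compound 2 and compound 3 lay within the scatter of each other. The step of an at least 110-fold lower number from compound 1 to compound 4 (2.07 log units; beyond the scatter) gives only a bound: the limit of > 100000 nM in this assay, at which 1 of the 4 values shown sits.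

Open, on these data alone, is whether the result for compound 4 needs the carboxylic acid itself or would hold with a methyl ester, an amide or a tetrazole in its place. Also open, as far as these compounds go, is how far the shared core can change while the 3-carboxyphenyl ring stays.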